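The compounds below may be only part of what the source reports. "The series", "measured", "known", "first", "only" and "open" are said of these compounds alone.

Within the data shown here, in a physicochemical assay for lipophilicity, read by HPLC (a lower number here means a more polar compound, a higher number a more lipophilic compound), compound 1 `CN(C)Cc1ccc(NC(=O)Nc2cccnc2Oc2ccccc2C(C)(C)C)c(F)c1` gives 4.2, the lower of the two numbers so far, while compound 2 `CN(C)CC(C)(C)COc1ccc(NC(=O)Nc2cccnc2Oc2ccccc2[Si](C)(C)C)cc1` gives 4.7, a gap beyond the scatter. Compound 3 `CC(C)N1CCC(COc2ccc(NC(=O)Nc3cccnc3Oc3ccccc3C(C)(C)C)c(F)c2)CC1` keeps the core of compound 1 but carries (1-isopropylpiperidin-4-yl)methoxy in place of (dimethylamino)methyl on an aromatic carbon. Among the measured compounds shown here, no measured pair isolates this change, and the only guide is compound 2 at 4.7, which also carries an oxygen-linked amine group. An upward step in this assay is expected, estimated as a number 0.70 log units higher from compound 1 to compound 3 (beyond the scatter). Compound 3 is expected at 4.9, with an estimated range of 4.4 to 5.4.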

Compound 3, partition coefficient: 3.8
Compound 3: middle estimate off by 1.10 log units, on the high side, outside the stated range (below it).
By their numbers in this assay, from the lowest: compound 3; then compound 1; then compound 2.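

In this assay, among these compounds, the swap to (1-isopropylpiperidin-4-yl)methoxy on this aromatic carbon gives a number 0.40 log units lower from compound 1 to compound 3 (beyond the scatter) and so gives the first measured step at this position. The number falls even though the entering group holds more carbon atoms and a six-membered non-aromatic ring. No measurement shown here explains the direction of this step. From the compounds shown here alone, the change alters the linking oxygen, the ring and the isopropyl group at once, so their separate shares remain open. A piperidin-4-ylmethoxy group without the isopropyl, or a 2-(dimethylamino)ethoxy chain, would begin to separate them.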